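A few compounds are considered here, and "the series" means these few. Any claim that something is new, unique, unknown or untested is made for them only; others in the source may bear on it.

Measured so far:
Compound 1 `O=S(=O)(/C=C/c1ccccc1)Cc1ccc(Nc2ncnc3ccccc23)cc1`: > 100000 nM, a limit
Compound 2 `O=S(=O)(/C=C/c1ccc(Cl)c(Cl)c1)Cc1ccc(Nc2ncnc3ccccc23)cc1`: 35000 nM
Compound 3 `O=S(=O)(/C=C/c1ccc(F)cc1F)Cc1ccc(Nc2ncnc3ccccc23)cc1`: > 100000 nM, a limit

Going by the values given here, in a functional assay on PC-3 cells (Homo sapiens) (on this read-out higher numbers stand for weaker inhibition of growth and lower numbers for stronger inhibition of growth), compound 2 is the only compound with a number, 35000 nM. The other two values are limits: the limit of > 100000 nM in this assay, at which 2 of the 3 values shown sit.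

Compound 4 `O=S(=O)(/C=C/c1ccc(Cl)c(Cl)c1)Cc1ccc(Nc2ncnc3ccc(Br)cc23)cc1` differs from compound 2 on the shared core: bromo in place of hydrogen on an aromatic carbon. Among the compounds with values here, no measured step touches that site. The nearest guides are halogen changes on the phenyl of the chain: an at least 2.8-fold lower number from compound 1 to compound 2 (0.45 log units; beyond the scatter) and an at least 2.8-fold higher number from compound 2 to compound 3 (0.45 log units; beyond the scatter). Compound 2 gained on that change, but compound 3 did not, so the direction is uncertain. A modest fall in the number is expected, and the expected step is a 1.8-fold lower number from compound 2 to compound 4 (0.24 log units; within the scatter). For compound 4 the estimated value is 20000 nM, with an expected range of 5000 nM to 80000 nM.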

Compound 4, concentration for 50% growth inhibition: 11000 nM
The estimate for compound 4 lay 1.8-fold (0.26 log units) above the measured number; low and high end bracket the measured number.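

In this assay, bromo in place of hydrogen gives a 3.2-fold lower number from compound 2 to compound 4 (0.50 log units; beyond the scatter), so the number responds to a change on the shared core and not only to halogens on the phenyl of the chain. A single added heavy atom on this aromatic carbon is enough for a step beyond the scatter. This holds for the 3,4-dichlorophenyl chain alone, because the other two chains stop at a limit: the limit of > 100000 nM in this assay, at which 2 of the 4 values shown sit.

On these data alone, whether bromo would also lower the number on the phenyl or 2,4-difluorophenyl chains stays open. So does whether chloro, methoxy or an amine on this carbon would move it the same way.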